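The compounds below may be only part of what the source reports. "The series", "measured", "known", "first", "only" and "open" are said of these compounds alone.

Measured compounds:
compound 1 `COc1ccc(-n2c(=O)c(C(=O)Nc3ccc(Oc4ccnc5[nH]ccc45)cc3)cc3cccnc32)cc1` gives 1260 nM in a functional assay on HT-29 cells (Homo sapiens) for antiproliferative activity, read by MTT assay, with a stated time of 72 h; a higher number here means a weaker inhibitor, a lower number a stronger inhibitor
compound 2 `O=C(Nc1ccc(Oc2ccnc3[nH]ccc23)cc1)c1cc2cccnc2n(-c2ccc(Br)cc2F)c1=O` gives 2360 nM in this assay

Among the two numbers so far, compound 2 has the highest, and the only other compound, compound 1, sits at 1260 nM; the change between them, a 1.9-fold higher number from compound 1 to compound 2 (0.27 log units; within the scatter), falls within the usual scatter of repeated measurements, so the two compounds cannot be told apart on this evidence.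

Compound 3 `Cn1ccc2c(Oc3ccc(NC(=O)c4cc5cccnc5n(-c5ccc(Br)cc5F)c4=O)cc3)ccnc21` has not yet been measured. It differs from compound 2 at a single place: methyl in place of hydrogen on an aromatic nitrogen.

Among the measured compounds shown here, no measured step touches this place. For the measured compounds named here, the one step known, from compound 1 to compound 2, concerns a different part of the molecule and was itself within the scatter. There is therefore nothing in the data that points to a change in this assay in either direction, and no step beyond the scatter is expected.

The expectation for compound 3 is that it will stay close to compound 2, with an estimated step of a 1.0-fold higher number from compound 2 to compound 3 (0.01 log units; within the scatter). The estimate for compound 3 is 2400 nM, with a range from 900 nM to 6500 nM.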

Compound 3, half-maximal inhibitory concentration: 2580 nM
For compound 3 the middle estimate is 1.1-fold (0.03 log units) below the measured one, and the stated range covers the measured number.
By their numbers in this assay, from the lowest: compounds 1, 2 and 3 (each within the scatter of the next, the first and the last beyond it).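

In this assay, among the compounds shown here, the first measured step at this place is methyl in place of hydrogen on the aromatic nitrogen of the five-membered ring, which gives a 1.1-fold higher number from compound 2 to compound 3 (0.04 log units; within the scatter) and leaves compound 2 and compound 3 indistinguishable on this evidence. The earlier step from compound 1 to compound 2 concerned the group on the other aromatic nitrogen, so it said nothing about this nitrogen; now a hydrogen on this nitrogen can be seen to be replaceable by a single carbon without a readable difference in this assay. No supporting measurement bears on what this result means for the compounds in the cells.

The single pair shown carries the 4-bromo-2-fluorophenyl group, so it remains open whether methyl on this nitrogen would give the same outcome with the 4-methoxyphenyl group of compound 1. From the compounds shown here alone, it is also open whether this nitrogen would accept something larger than methyl, such as an ethyl group, a longer carbon chain or a chain ending in an amine, with as little visible difference.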